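This account rests on a few compounds, and the source may have more. Where it says the series, first, only, none or still open, it means among the compounds named here.

Of the compounds shown here, two have so far been measured in an assay on isolated protein for binding affinity to Equilibrative nucleoside transporter 1 (Homo sapiens); on this read-out higher numbers stand for weaker inhibition and lower numbers for stronger inhibition. Compound 1 `O=[N+]([O-])c1ccc2c(c1)CN(c1ncnc3c1ncn3[C@@H]1O[C@H](CO)[C@@H](O)[C@H]1O)CC2` gives 5.5 nM in this assay. Compound 2 `OC[C@H]1O[C@@H](n2cnc3c(NCc4ccco4)ncnc32)[C@H](O)[C@@H]1O` gives 36300 nM in this assay, the higher of the two numbers, and its distance from compound 1 lies far beyond the usual scatter, so compound 2 is clearly the weaker inhibitor of the pair. The step under consideration leads from compound 2 to compound 3 `OC[C@H]1O[C@@H](n2cnc3c(SC4CCCCC4)ncnc32)[C@H](O)[C@@H]1O`, which differs in a single place: cyclohexylsulfanyl in place of ((furan-2-yl)methyl)amino on an aromatic carbon. Among the compounds with values here, no measured pair differs in just one place, so there is no direct precedent for the size of this change. The expectation for compound 3 is a move towards a lower number than compound 2 shows, the expected step being a 12-fold lower number from compound 2 to compound 3 (1.08 log units; beyond the scatter) in this assay. Compound 3 is therefore estimated at 3000 nM in this assay, with a plausible range from 300 nM to 30000 nM.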

Compound 3, half-maximal inhibitory concentration: 6310 nM
For compound 3 the middle estimate is 2.1-fold (0.32 log units) below the measured one, within the range that was stated.
By their numbers in this assay, from the lowest: compound 1; then compound 3; then compound 2.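

In this assay, this first pair differing in one place gives a 5.8-fold lower number from compound 2 to compound 3 (0.76 log units; beyond the scatter) and so shows that the position responds to what sits on it. On this aromatic carbon, ((furan-2-yl)methyl)amino, with its five-membered aromatic ring and hydrogen-bond donor, can give way to cyclohexylsulfanyl, with its non-aromatic carbon ring and no hydrogen-bond donor, and inhibition still improves. No measurement at hand accounts for this step. The swap changes the linking atom and the ring at once, so the pair cannot say which of the two matters; cyclohexylamino or cyclohexyloxy on the same carbon would separate them. On these data alone, how far the position tolerates other sizes also stays open, for instance with methylsulfanyl or benzylsulfanyl.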